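Anilino substituent variation in a shared nitrile core series

A few compounds are considered here, and "the series" means these few. Any claim that something is new, unique, unknown or untested is made for them only; others in the source may bear on it.

Compound 1 `CC(C)c1ccc(-c2nc(SCc3cn(CC(=O)NC(=O)Nc4ccccn4)nn3)nc(Nc3ccc(F)cc3)c2C#N)cc1` and compound 2 `COc1ccc(Nc2nc(SCc3cn(CC(=O)NC(=O)Nc4ccccn4)nn3)nc(-c3ccc(C(C)C)cc3)c2C#N)cc1` share the whole core and differ only in the group on the anilino ring. In a functional assay on MCF7 cells (Homo sapiens) for inhibition, read by MTT assay, with a stated time of 72 h (on this read-out lower numbers stand for stronger inhibition and higher numbers for weaker inhibition), compound 1 returns no number, only an assay limit, > 64000 nM. In this assay compound 2 likewise returns only a limit, > 64000 nM. Among the measured compounds shown here, compound 2 therefore stands at the ceiling of what this assay reports, and the one further value shown is also a limit, as the limit of > 64000 nM in this assay, at which 2 of the 2 values shown sit, records. The step that the two limits leave unreadable from compound 1 to compound 2, methoxy in place of fluoro on an aromatic carbon, is of unreadable size, as two limits bracket it.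

Compound 3 `Cc1ccc(Nc2nc(SCc3cn(CC(=O)NC(=O)Nc4ccccn4)nn3)nc(-c3ccc(C(C)C)cc3)c2C#N)cc1` awaits measurement. It differs from compound 2 by methyl in place of methoxy on an aromatic carbon; cut one bond further out, this reads 4-methoxyphenyl to 4-methylphenyl. For the measured compounds named here, the single measured step, from compound 1 to compound 2, touches the same ring but yields no readable size, so no step beyond scatter can be anticipated in either direction. Compound 3 is expected near 90000 nM, within 30000 nM to 300000 nM, most likely again reported only as a limit. The step expected here is a step that the limit leaves unreadable from compound 2 to compound 3.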

Compound 3, half-maximal inhibitory concentration: > 64000 nM
Compound 3 was reported as a limit; the forecaster's own chance of this, stated with the estimate: 80%; the middle value does not contradict the limit.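

In this assay compound 3 returns only a limit, > 64000 nM. Compound 1, compound 2 and compound 3 are therefore joined by no readable step, and all three stand at one reported limit: the limit of > 64000 nM in this assay, at which 3 of the 3 values shown sit.

The compounds shown leave open whether any group on the anilino ring of this shared core gives a measurable value in this assay.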